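Amine substituent swap: cytotoxicity outlook for compound 4

This account rests on a few compounds, and the source may have more. Where it says the series, first, only, none or still open, it means among the compounds named here.

Compound 3 `Cc1ccc2[nH]c(=O)c(CN(Cc3ccc(C(C)(C)C)cc3)[C@H](CO)c3ccccc3)cc2c1` is known only as a limit in a toxicity assay on MDCK cells (Canis lupus familiaris) for cytotoxicity, read by crystal violet staining, with a stated time of 48 h; on this read-out higher numbers stand for lower toxicity in this test and lower numbers for higher toxicity in this test; compound 3 gives > 10000 nM there. Compound 1 `Cc1ccc2[nH]c(=O)c(CN(Cc3ccc(F)cc3)Cc3ccc(C(C)(C)C)cc3)cc2c1` likewise shows only a limit, > 27000 nM, in this assay. Compound 2 `CSc1ccc(CN(Cc2ccc(C(C)(C)C)cc2)Cc2cc3cc(C)ccc3[nH]c2=O)cc1` also shows a limit, > 5000 nM, in this assay. Since (the limit of > 10000 nM in this assay, at which 1 of the 3 values shown sits), the limit of > 27000 nM in this assay, at which 1 of the 3 values shown sits, and the limit of > 5000 nM in this assay, at which 1 of the 3 values shown sits, each record a limit, compound 3 cannot be placed above or below compound 1 or compound 2 in this assay.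

The change to compound 4 `Cc1ccc2[nH]c(=O)c(CN(Cc3ccc(C(C)(C)C)cc3)[C@H](C)c3ccc(F)cc3)cc2c1` is 1-(4-fluorophenyl)ethyl in place of 2-hydroxy-1-phenylethyl on an amine nitrogen. The measured steps that touch the same amine nitrogen, a step that the two limits leave unreadable from compound 1 to compound 3 and a step that the two limits leave unreadable from compound 2 to compound 3, and the ring substituent step that the two limits leave unreadable from compound 1 to compound 2, are all unreadable, as both ends of each sit at limits. For a step that the limit leaves unreadable from compound 3 to compound 4 no step beyond the scatter is expected in either direction. Compound 4 is therefore estimated at 20000 nM in this assay, within a range of 5000 nM to 60000 nM, and is expected most likely to return a limit again.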

Compound 4, half-maximal cytotoxic concentration: > 5000 nM
Compound 4: a limit, no number (the forecaster's own chance of this, stated with the estimate: 85%); the middle value is on the limit's open side.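

In this assay compound 4 gives > 5000 nM as a limit. All four values are limits, and the steps linking compound 4 to compound 1, compound 2 and compound 3 cannot be read. The compounds shown leave open whether any substituent on the amine nitrogen changes cytotoxicity.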